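A few compounds are considered here, and "the series" means these few. Any claim that something is new, unique, unknown or untested is made for them only; others in the source may bear on it.

In an ADME assay on Raji cells (Homo sapiens) for cytotoxicity, read by CellTiter-Glo and resazurin assay, with a stated time of 72 h (a lower number here means that less compound is needed, a higher number that more compound is needed for the effect), compound 3 `CCOC(=O)CCCCCOc1cccc(CN(C(=O)c2ccc(-c3ccco3)cc2)C(C)C)c1` gives only a limit of the assay, > 26000 nM. Compound 1 `CCOC(=O)CCCCCOc1cccc(CN(C(=O)c2ccc(-c3cccc4ccccc34)cc2)C(C)C)c1` likewise stands at a limit in this assay, > 26000 nM. Compound 2 `CCOC(=O)CCCCCOc1cccc(CN(C(=O)c2ccc(-c3ccncc3)cc2)C(C)C)c1` also reaches only a limit in this assay, > 26000 nM. All three values therefore share one mark, (the limit of > 26000 nM in this assay, at which 3 of the 3 values shown sit), and none of the three steps among them can be read: the step that the two limits leave unreadable from compound 1 to compound 2, the step that the two limits leave unreadable from compound 1 to compound 3 and the step that the two limits leave unreadable from compound 2 to compound 3 are each hidden between two limits.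

Compound 4 `CCOC(=O)CCCCCOc1cccc(CN(C(=O)c2ccc(-c3cc(OC)cc(OC)c3)cc2)C(C)C)c1` is not yet measured in this assay. It differs from compound 3 by 3,5-dimethoxyphenyl in place of furan-2-yl on an aromatic carbon. Among the measured compounds shown here, the three measured steps bear on this change only in that every exchange of the aryl group seen so far left the value at the limit, so no size of step is readable from them. He expects the step that the limit leaves unreadable from compound 3 to compound 4 to be none beyond the scatter, with compound 4 most likely again returning a limit. His estimate for compound 4 in this assay is 30000 nM, within a range from 12000 nM to 100000 nM.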

Compound 4, half-maximal effective concentration: > 26000 nM
Compound 4: no number, only a limit (the forecaster's own chance of this, stated with the estimate: 85%); the middle value is on the limit's open side.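

Compound 4 also returns only a limit in this assay, so no step between it and compound 1, compound 2 or compound 3 can be read: the limit of > 26000 nM in this assay, at which 4 of the 4 values shown sit.

The compounds shown leave open whether any aryl group at this place would give a readable value in this assay.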